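Replacing phenyl with naphthalen-1-yl in a cytotoxicity series

The compounds below may be only part of what the source reports. "The series", "measured", "known", "first", "only" and "open" are said of these compounds alone.

Measured so far:
compound 1 `COc1ccc(Oc2ccc3c(NCCCNCc4cc(F)ccc4OC)ccnc3c2)cc1`, 7000 nM
compound 2 `COc1ccc(F)cc1CNCCCNc1ccnc2cc(CCC(C)C)ccc12`, 890 nM
compound 3 `COc1ccc(F)cc1CNCCCNc1ccnc2cc(-c3ccccc3)ccc12`, 2960 nM

These three share a core and differ in one group on an aromatic carbon. In an ADME assay on HepG2 cells (Homo sapiens) for cytotoxicity, read by luminescence, CellTiter-Glo and ATP content, with a stated time of 72 h (a lower number here means that less compound is needed, a higher number that more compound is needed for the effect), compound 3 stands second highest of the three numbers: the step of a 3.3-fold higher number from compound 2 to compound 3 (0.52 log units; beyond the scatter) sets it apart from compound 2, while a 2.4-fold lower number from compound 1 to compound 3 (0.37 log units; beyond the scatter) places it nearer compound 1. Compound 4 `COc1ccc(F)cc1CNCCCNc1ccnc2cc(-c3cccc4ccccc34)ccc12` changes this same position: naphthalen-1-yl in place of phenyl on an aromatic carbon. For the measured compounds named here, no measured step shows a second aromatic ring entering here, so the steps of a 7.9-fold lower number from compound 1 to compound 2 (0.90 log units; beyond the scatter) and a 3.3-fold higher number from compound 2 to compound 3 (0.52 log units; beyond the scatter) only frame the range seen at this position. A small step toward a lower number is expected, a 1.5-fold lower number from compound 3 to compound 4 (0.17 log units; within the scatter), with wide uncertainty. Compound 4 is estimated at 2000 nM, between 700 nM and 6000 nM.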

Compound 4, half-maximal effective concentration: 16000 nM
Compound 4: middle estimate off by 8.0-fold (0.90 log units), on the low side; the measured number lies above the stated range.
By their numbers in this assay, from the lowest: compound 2; then compound 3; then compound 1; then compound 4.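

In this assay, naphthalen-1-yl in place of phenyl gives a 5.4-fold higher number from compound 3 to compound 4 (0.73 log units; beyond the scatter), so adding a second aromatic ring at this position raises the number rather than leaving it near that of phenyl. Compound 4 also stands beyond the other two groups, with an 18-fold higher number from compound 2 to compound 4 (1.25 log units; beyond the scatter) and a 2.3-fold higher number from compound 1 to compound 4 (0.36 log units; beyond the scatter), which makes naphthalen-1-yl the highest of the four and widens the range seen at this position. Nothing measured here explains this rise. Still open, as far as these compounds go, is whether naphthalen-2-yl would give a similarly high number, and whether a longer chain ending in an amine would stay near the low number of compound 2.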